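A few compounds are considered here, and "the series" means these few. Any claim that something is new, unique, unknown or untested is made for them only; others in the source may bear on it.

Measured so far:
- compound 1 `O=C(/C=C/c1cccnc1)NCCCCCCc1ccc(S(=O)(=O)Nc2ccccc2)cc1`: 328 nM
- compound 2 `O=C(/C=C/c1cccnc1)NCCCCCCc1cccc(S(=O)(=O)Nc2ccccc2)c1`: 6.73 nM

Both values come from a functional assay on DU-145 cells (Homo sapiens) for inhibition, read by CCK-8 assay, with a stated time of 72 h; on this read-out higher numbers stand for weaker inhibition and lower numbers for stronger inhibition. Of the two numbers, compound 2 has the lower one at 6.73 nM, and the gap to compound 1 at 328 nM lies well beyond the scatter.

The next compound is compound 3 `Cc1ccc(C)c(NS(=O)(=O)c2cccc(CCCCCCNC(=O)/C=C/c3cccnc3)c2)c1`, which has not yet been measured. It keeps everything in compound 2 except one group: 2,5-dimethylphenyl in place of phenyl on a sulfonamide nitrogen. In words, 2,5-dimethylphenyl stands in place of phenyl on a sulfonamide nitrogen.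

Going by the values given here, no measured pair shows a change at this place, so the expectation is loose. In this assay, a modest move towards a higher number is expected, possibly no larger than the scatter. The estimated change is a 1.5-fold higher number from compound 2 to compound 3 (0.17 log units; within the scatter). For compound 3 the estimated value is 10 nM, with an expected range of 2 nM to 50 nM.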

Compound 3, half-maximal inhibitory concentration: 7.48 nM
Compound 3: the middle estimate sits 1.3-fold (0.13 log units) above what was measured; measured number inside the range.
By their numbers in this assay, from the lowest: compounds 2 and 3 (each within the scatter of the next); then compound 1.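

In this assay, going by these compounds alone, the first change at this place, 2,5-dimethylphenyl in place of phenyl on a sulfonamide nitrogen, gives a 1.1-fold higher number from compound 2 to compound 3 (0.05 log units; within the scatter). The group on this nitrogen can therefore grow from 6 to 8 heavy atoms, all carbon, with no change in the read-out beyond the scatter, so this place accepts at least this one substitution on the ring. No supporting measurement bears on this result, and the two values alone do not say what lies behind it.

Going by these compounds, it remains open whether a group of another kind on that ring, such as an amine, a carboxylic acid or a methoxy group, would leave the number as unchanged, or whether a pyridine ring could stand in place of the phenyl. Also open, on these data alone, is whether 2,5-dimethylphenyl would give the same result on the core of compound 1.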